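Amide cap variation on a shared dichloro-aryl triazolopyridine core

A few compounds are considered here, and "the series" means these few. Any claim that something is new, unique, unknown or untested is made for them only; others in the source may bear on it.

Three amides built on the same core have been examined in a functional assay on U-251 cells (Homo sapiens) for antiproliferative activity, read by MTT assay, with a stated time of 72 h; a higher number here means a weaker inhibitor, a lower number a stronger inhibitor. Compound 1 `CS(=O)(=O)c1ccc(C(=O)Nc2ccc(Cl)c(-c3nnc4c(Cl)cccn34)c2)c(Cl)c1` carries a 2-chloro-4-methylsulfonylphenyl group on the carbonyl carbon and in this assay compound 1 gives 44600 nM. Compound 2 `Cc1cc(Cl)ccc1C(=O)Nc1ccc(Cl)c(-c2nnc3c(Cl)cccn23)c1` carries a 4-chloro-2-methylphenyl group in the same place; in this assay compound 2 gives only a limit of the assay, > 100000 nM. Compound 3 `O=C(Nc1ccc(Cl)c(-c2nnc3c(Cl)cccn23)c1)c1ccon1` carries a 1,2-oxazol-3-yl group on the carbonyl carbon; in this assay compound 3 also gives only a limit, > 100000 nM. Among the measured compounds shown here, the one step that joins two measured compounds, a step that the two limits leave unreadable from compound 2 to compound 3, cannot be read in size, since both ends rest on (the limit of > 100000 nM in this assay, at which 2 of the 3 values shown sit).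

Compound 4 `O=C(Nc1ccc(Cl)c(-c2nnc3c(Cl)cccn23)c1)c1ccc(Cl)cc1Cl` differs from compound 3 in one place: 2,4-dichlorophenyl in place of 1,2-oxazol-3-yl on a carbonyl carbon. For the measured compounds named here, no measured step covers this change; the nearest comparison is compound 2, whose substituted phenyl cap sits at the limit, while compound 1 with its methylsulfonyl-bearing phenyl is the only member with a number. For compound 4 the expectation is therefore a value close to the limit, with an at least 1.2-fold lower number from compound 3 to compound 4 (0.09 log units; that floor lies within the scatter) expected to be small or not readable. Compound 4 is estimated at 80000 nM, within 30000 nM to 200000 nM, with a real chance that only a limit is reported.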

Compound 4, half-maximal inhibitory concentration: > 100000 nM
Compound 4 was reported as a limit; the forecaster's own chance of this, stated with the estimate: 55%; middle value at least 1.2-fold (0.09 log units) away from the limit.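

In this assay compound 4 gives > 100000 nM as a limit and not a number. Chloro in place of methylsulfonyl on an aromatic carbon is the first change in the series that can be read in size, as an at least 2.2-fold higher number from compound 1 to compound 4 (0.35 log units; beyond the scatter) and so lies beyond the scatter, though its true size may be larger than this floor. The other two steps that end at compound 4 cannot be read, whether the change is 2,4-dichlorophenyl in place of 1,2-oxazol-3-yl on the carbonyl carbon or chloro in place of methyl on an aromatic carbon, since both ends of each rest on one ceiling: (the limit of > 100000 nM in this assay, at which 3 of the 4 values shown sit).

Still open, going by these compounds, is whether the measurable value depends on methylsulfonyl in particular, or whether another group on that aromatic carbon, such as a carboxylic acid, an amine or a sulfonamide, would also bring a cap off the limit. Any order among compound 2, compound 3 and compound 4 also remains unknown, and so does how far compound 4 actually lies from compound 1 in this series.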